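The source may report more compounds than this note shows. Statements on the series, on what has been measured and on what is new or still open speak of the compounds shown alone.

Series notes. Going by the values given here, compound 2 `Cc1cccc(NC(=O)CSc2nnc(-c3ccoc3C)n2Cc2ccco2)c1` gives 50.1 nM in a functional assay on CHO cells for antagonist activity at Orexin receptor type 2 (Homo sapiens), read by FLIPR and calcium flux (a lower number here means a stronger inhibitor, a higher number a weaker inhibitor), and stands lowest of the three numbers so far. Compound 3 `Cc1occc1-c1nnc(SCC(=O)Nc2cccc(Cl)c2)n1Cc1ccco1` gives 63.1 nM in this assay, and the pair lie within the scatter of each other: a 1.3-fold higher number from compound 2 to compound 3 (0.10 log units; within the scatter). Compound 1 `Cc1ccc(C)c(NC(=O)CSc2nnc(-c3ccoc3C)n2Cc2ccco2)c1` gives 398 nM in this assay; the steps of a 7.9-fold lower number from compound 1 to compound 2 (0.90 log units; beyond the scatter) and a 6.3-fold lower number from compound 1 to compound 3 (0.80 log units; beyond the scatter) both show that changing the aryl on the amide-type nitrogen can move the number well beyond the scatter.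

Compound 4 `CC(=O)c1ccc(NC(=O)CSc2nnc(-c3ccoc3C)n2Cc2ccco2)cc1` carries 4-acetylphenyl in place of 3-methylphenyl on an amide-type nitrogen. Among the compounds with values here, no measured step covers an acetyl group, and the only aryl changes measured so far are the loss of one methyl and a swap of chloro for methyl. The step of a 3.2-fold higher number from compound 2 to compound 4 (0.50 log units; beyond the scatter) is expected to be a modest rise in this assay, with wide uncertainty. This rests on compound 1, whose value 398 nM shows that a changed aryl pattern can cost much, and on compound 3, whose step a 1.3-fold higher number from compound 2 to compound 3 (0.10 log units; within the scatter) shows a small swap need not. Compound 4 is estimated at 160 nM in this assay, ranging from 40 nM to 700 nM.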

Compound 4, inhibition constant: 31.6 nM
Compound 4: middle estimate off by 5.1-fold (0.70 log units), on the high side; the measured number lies below the stated range.
By their numbers in this assay, from the lowest: compounds 4, 2 and 3 (each within the scatter of the next); then compound 1.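

The aryl on the amide-type nitrogen in this assay accepts 4-acetylphenyl, with its carbonyl and hydrogen-bond acceptor, and stays within the scatter of both 3-methylphenyl and 3-chlorophenyl: a 1.6-fold lower number from compound 2 to compound 4 (0.20 log units; within the scatter) and a 2.0-fold lower number from compound 3 to compound 4 (0.30 log units; within the scatter). Tolerance at this position therefore reaches beyond a methyl or chloro swap to an acetyl group, while 2,5-dimethylphenyl remains the aryl that stands apart, with a 13-fold lower number from compound 1 to compound 4 (1.10 log units; beyond the scatter). Nothing available explains this tolerance.

The compounds shown leave open whether the acetyl carbonyl itself contributes, a question that 4-methylphenyl, 4-aminophenyl or 4-carboxyphenyl on the same nitrogen would address. They also leave open whether the higher number of compound 1 traces to one of its two methyl groups or needs both.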